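The source may hold more compounds than are shown below. What is called first, only, known or untested is meant among the compounds shown, and "the series" means these compounds.

Values in a functional assay on HOS-TE85 cells (Homo sapiens) for inhibition, read by CCK-8 assay, with a stated time of 72 h; on this read-out lower numbers stand for stronger inhibition and higher numbers for weaker inhibition:
- Compound 1 `COc1ccc(OC)c(N2C(=O)CSC2c2cccc(C(=O)NCCCCc3ccccc3)c2)c1`: > 1000 nM (a limit)
- Compound 2 `CCN(CC)c1ccc(N2C(=O)CSC2c2cccc(C(=O)NCCCCc3ccccc3)c2)cc1`: > 1000 nM (a limit)
- Compound 3 `Cc1cccc(N2C(=O)CSC2c2cccc(C(=O)NCCCCc3ccccc3)c2)c1`: 93.2 nM

Going by the values given here, compound 3 is the only compound with a number, while the other two sit at the limit of > 1000 nM in this assay, at which 2 of the 3 values shown sit. Compound 4 `O=C(NCCCCc1ccccc1)c1cccc(C2SCC(=O)N2c2cccc(-c3c[nH]nn3)c2)c1` carries 1H-1,2,3-triazol-4-yl in place of methyl on an aromatic carbon.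

Among the compounds with values here, two measured steps bear on this aryl group, both large: an at least 10-fold lower number from compound 1 to compound 3 (1.03 log units; beyond the scatter) and an at least 10-fold lower number from compound 2 to compound 3 (1.03 log units; beyond the scatter). Neither involves a triazolyl group, so they fix the size of the new step only loosely. Starting from compound 3 at 93.2 nM, a moderately higher number is expected in this assay. The expected step is a 2.7-fold higher number from compound 3 to compound 4 (0.43 log units; beyond the scatter). The estimate for compound 4 is 250 nM, with an expected range from 30 nM to 1800 nM.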

Compound 4, half-maximal inhibitory concentration: 110 nM
Compound 4: middle estimate off by 2.3-fold (0.36 log units), on the high side; measured number inside the range.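

In this assay, the ring position meta to a large group accepts 1H-1,2,3-triazol-4-yl in place of methyl, with the two compounds level within the scatter (a 1.2-fold higher number from compound 3 to compound 4 (0.07 log units; within the scatter)). The triazolyl aryl group keeps the separation from the other two aryl groups (an at least 9.0-fold lower number from compound 2 to compound 4 (0.95 log units; beyond the scatter); an at least 9.0-fold lower number from compound 1 to compound 4 (0.95 log units; beyond the scatter)). Compound 1 and compound 2 each stand at a limit, not a number: (the limit of > 1000 nM in this assay, at which 2 of the 4 values shown sit).

Going by these compounds, whether a carboxylic acid, an amine or a 1-methyl-1,2,3-triazolyl group at this position would also match methyl stays open. So does the effect of either group at other positions on this aromatic ring.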